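A few compounds are considered here, and "the series" means these few. Any claim that something is new, unique, unknown or untested is made for them only; others in the source may bear on it.

Of the compounds shown here, two of one shared core have been measured in a functional assay on the whole organism with Rattus norvegicus as the target, at a dose of 20 mg/kg by the oral route; on this read-out lower numbers stand for less inhibition and higher numbers for more inhibition at the one dose given (going by the name of the read-out). Compound 1, `O=C(/C=C1\CCc2cc(Cl)ccc21)NC1CC1`, gives 34%, and compound 2, `NC(=O)/C=C1\CCc2cc(Cl)ccc21`, gives 30%; the two values lie within the scatter of each other, so the step of a number 4 percentage points lower from compound 1 to compound 2 (within the scatter) marks no real change on this read-out. Compound 3, `CNC(=O)/C=C1\CCc2cc(Cl)ccc21`, has not yet been measured. It differs from compound 2 by methyl in place of hydrogen on an amide-type nitrogen. Within the data shown here, the only measured step that bears on this change is the one from compound 1 to compound 2, which also altered the group on the amide-type nitrogen and moved the read-out only within the scatter. A small group entering at the same place is therefore expected to produce no step beyond the scatter, and the expected step from compound 2 to compound 3 is a number 2 percentage points higher from compound 2 to compound 3 (within the scatter). Compound 3 is thus estimated at 32%, with a range from 20% to 45%.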

Compound 3, a percentage reported as inhibition, in the whole organism at one dose (the size of the read-out at that dose, not a potency): 40%
Compound 3: the middle estimate sits 8 percentage points below what was measured, within the range that was stated.
By their numbers in this assay, from the lowest: compounds 2, 1 and 3 (each within the scatter of the next).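

In this assay, methyl in place of hydrogen on the amide-type nitrogen gives a step that stays within the scatter (a number 10 percentage points higher from compound 2 to compound 3 (within the scatter)), and methyl in place of cyclopropyl does the same (a number 6 percentage points higher from compound 1 to compound 3 (within the scatter)). Hydrogen, methyl and cyclopropyl on this nitrogen therefore read alike at the one dose given, whereas the earlier pair could show this only for hydrogen and cyclopropyl. Nothing at hand gives a reason for these numbers.

Going by these compounds, it remains open whether a longer chain such as n-butyl, or a benzyl group, on this nitrogen would give a step beyond the scatter. On these data alone, it also remains open how a second methyl on the same nitrogen, or a carboxylic acid in place of the whole amide, would read.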